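This account rests on a few compounds, and the source may have more. Where it says the series, first, only, none or still open, it means among the compounds named here.

Compound 2 `O=C(NCCCCN1CCN(c2ccc(O)cc2)CC1)c1ccc(-c2ccsc2)cc1` and compound 1 `O=C(NCCCCN1CCN(c2ccccc2O)CC1)c1ccc(-c2ccsc2)cc1` share one core and differ only in where a hydroxyl sits on a phenyl ring attached to an amine nitrogen in a ring. For the measured compounds named here, in an ADME assay on microsomes from liver (Rattus norvegicus) for metabolic stability, read by LC-MS, using NADPH (a higher number here means that the compound lasts longer, a lower number that the compound disappears faster), compound 2 gives 0.19 h, the higher of the two numbers so far, while compound 1 gives 0.157 h. The step of a 1.2-fold higher number from compound 1 to compound 2 (0.08 log units; within the scatter) lies within the scatter, so the two compounds cannot be told apart on these numbers.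

Compound 3 `O=C(NCCCCN1CCN(c2cccc(C(F)(F)F)c2)CC1)c1ccc(-c2ccsc2)cc1` differs from compound 2 in one place: 3-(trifluoromethyl)phenyl in place of 4-hydroxyphenyl on an amine nitrogen in a ring. Going by the values given here, the only measured step, from compound 1 to compound 2, moves a hydroxyl from one position to another and does not bear directly on the exchange of a 4-hydroxyphenyl for a 3-(trifluoromethyl)phenyl, so nothing measured here anchors the size of this step. With so little to go on, compound 3 is expected to stay close to compound 2, with a step of a 1.3-fold higher number from compound 2 to compound 3 (0.12 log units; within the scatter) that need not exceed the scatter. Compound 3 is therefore estimated at 0.25 h, with a range from 0.1 h to 0.6 h.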

Compound 3, half-life: 0.282 h
The estimate for compound 3 lay 1.1-fold (0.05 log units) below the measured number, and the stated range covers the measured number.
By their numbers in this assay, from the lowest: compounds 1, 2 and 3 (each within the scatter of the next).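

The earlier pair only moved a hydroxyl around the phenyl ring, whereas compound 3 has no hydroxyl at all and carries 3-(trifluoromethyl)phenyl on the amine nitrogen in the ring. In this assay, this much larger exchange gives two steps (a 1.5-fold higher number from compound 2 to compound 3 (0.17 log units; within the scatter) and a 1.8-fold higher number from compound 1 to compound 3 (0.25 log units; within the scatter)), and both lie within the scatter, so a group with no hydrogen-bond donor or acceptor cannot be told apart from either hydroxyphenyl group on these numbers, even though the leaving and entering groups differ in their atoms and heavy-atom counts. Nothing available here explains why the three numbers lie so close together.

The three compounds do not show whether any group at this position can move the half-life beyond the scatter, since each one carries a phenyl ring with a single neutral group on it. A phenyl ring bearing a carboxylic acid or an amine would test this position with quite different atoms, and a longer or shorter chain in the shared core would show whether another part of the molecule matters more.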